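The source may hold more compounds than are shown below. What is called first, only, known or untested is meant among the compounds shown, and "the series" means these compounds.

Compound 1 `Cc1ccn2c(CN3CCCCC3)c(-c3ccccc3)nc2n1`: 1710 nM
Compound 2 `c1ccc(-c2nc3ncccn3c2CN2CCCC2)cc1`: 70 nM
Compound 3 `c1ccc(-c2nc3ncccn3c2CN2CCCCC2)cc1`: 2280 nM

These values come from a functional assay on HeLa cells (Homo sapiens) for inhibition, read by sulforhodamine B assay, with a stated time of 48 h; a higher number here means a weaker inhibitor of growth, a lower number a stronger inhibitor of growth. Compound 3, at 2280 nM, lies at the weak end of this small set, alongside compound 1. Compound 4 `c1ccc(-c2nc3ncccn3c2CN2CCNCC2)cc1` keeps the shared core and changes one group on a saturated chain carbon bound to an aromatic carbon: piperazin-1-yl in place of piperidin-1-yl on a saturated chain carbon bound to an aromatic carbon. The closest evidence is a 33-fold higher number from compound 2 to compound 3 (1.51 log units; beyond the scatter), which shows that this place can matter, but that change is a different one. The other measured step, a 1.3-fold higher number from compound 1 to compound 3 (0.12 log units; within the scatter), lies elsewhere on the core. No firm direction follows, so little change is expected, with wide uncertainty. The estimate is a 1.1-fold lower number from compound 3 to compound 4 (0.06 log units; within the scatter). Compound 4 is expected at 2000 nM, within an estimated range of 400 nM to 9000 nM.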

Compound 4, concentration for 50% growth inhibition: 720 nM
Compound 4: middle estimate off by 2.8-fold (0.44 log units), on the high side; the range from low to high includes it.
By their numbers in this assay, from the lowest: compound 2; then compound 4; then compounds 1 and 3 (each within the scatter of the next).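

Among the six-membered rings at this saturated chain carbon, the piperazin-1-yl change, with its second ring nitrogen and one hydrogen-bond donor, gives a 3.2-fold lower number from compound 3 to compound 4 (0.50 log units; beyond the scatter) and so moves the number beyond the scatter. Ring identity at this place therefore matters beyond the pyrrolidin-1-yl to piperidin-1-yl step, yet piperazin-1-yl still leaves a 10-fold higher number from compound 2 to compound 4 (1.01 log units; beyond the scatter) as a large gap. No measurement here explains either shift.

The compounds leave open how a morpholin-4-yl or dimethylamino group would read at this place. They also leave open whether the methyl on the core of compound 1 would alter the piperazin-1-yl result.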